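Chloro on the sulfonyl phenyl of compound 2

A few compounds are considered here, and "the series" means these few. Any claim that something is new, unique, unknown or untested is made for them only; others in the source may bear on it.

Measured so far:
compound 1 `CCN1CCCC(n2cc(S(=O)(=O)c3ccccc3)c3ccccc32)C1`: 7.3 nM
compound 2 `O=S(=O)(c1ccccc1)c1cn(C2CCNC2)c2ccccc12`: 5 nM

In an assay on HeLa cells for displacement of a labelled ligand from 5-hydroxytryptamine receptor 6 (Homo sapiens), with a stated time of 2 h (on this read-out higher numbers stand for weaker inhibition and lower numbers for stronger inhibition), compound 2 gives 5 nM, the smaller of the two numbers, though its gap to compound 1 is within the scatter, as the step of a 1.5-fold lower number from compound 1 to compound 2 (0.16 log units; within the scatter) shows. Compound 3 `O=S(=O)(c1cccc(Cl)c1)c1cn(C2CCNC2)c2ccccc12` differs from compound 2 by chloro in place of hydrogen on an aromatic carbon. Within the data shown here, no measured step touches this phenyl; the one step seen concerns only the amine and is within the scatter. The change is therefore expected to move the number little, a 1.3-fold lower number from compound 2 to compound 3 (0.10 log units; within the scatter). Compound 3 is estimated at 4 nM, range 1.5 nM to 12 nM.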

Compound 3, inhibition constant: 3.2 nM
Estimate against measurement, compound 3: 1.3-fold (0.10 log units) above; the measured number falls inside the stated range.
By their numbers in this assay, from the lowest: compounds 3, 2 and 1 (each within the scatter of the next, the first and the last beyond it).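

In this assay the change from phenyl to 3-chlorophenyl gives a 1.6-fold lower number from compound 2 to compound 3 (0.19 log units; within the scatter), so this position on the sulfonyl phenyl takes a chloro without a change that can be told from the scatter. The earlier step concerned only the amine and showed nothing about this phenyl. No measured evidence bears on this result. Going by these compounds, it remains open whether a methoxy, a nitrile or an amine here would move the number beyond the scatter. Chloro at other places on this phenyl also remains open.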